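The compounds below may be only part of what the source reports. "The series", "measured", "known", "first", "only" and "open" are said of these compounds alone.

Measured compounds:
Compound 1, `C/N=C(\S)NCCCCCn1nc(-c2ccccc2)ccc1=O`, gives 42.1 mg/kg in a functional assay on the whole organism with Rattus norvegicus as the target; on this read-out higher numbers stand for an effect only at larger amounts of compound and lower numbers for an effect already at smaller amounts.
Compound 2, `CC/N=C(/NC#N)NCCCCn1nc(-c2ccccc2)ccc1=O`, gives 60.7 mg/kg in this assay.

Going by the values given here, compound 1 stands at the lowest of the two numbers so far, but its nearest neighbour, compound 2, sits a 1.4-fold higher number from compound 1 to compound 2 (0.16 log units; within the scatter) away, so the two values cannot be told apart. The unmeasured compound 3, `CC/N=C(\S)NCCCn1nc(-c2ccccc2)ccc1=O`, differs from compound 1 in one place: a group of 6 heavy atoms (3 carbon, 2 nitrogen, 1 sulfur; no ring) in place of a group of 7 heavy atoms (4 carbon, 2 nitrogen, 1 sulfur; no ring), on a saturated chain carbon, three bonds along the chain from an aromatic nitrogen. Among the compounds with values here, the only measured step available is the one from compound 1 to compound 2, and it was a 1.4-fold higher number from compound 1 to compound 2 (0.16 log units; within the scatter); that change touched the same end of the chain but exchanged a different pair of groups, so it bears on the present step only loosely. Within the data shown here, nothing among the measured compounds shows a change in this region moving the number beyond the scatter. The expected step from compound 1 to compound 3 in this assay is therefore a 1.1-fold higher number from compound 1 to compound 3 (0.03 log units; within the scatter), with no direction beyond the scatter claimed. Compound 3 is estimated at 45 mg/kg, within a range from 20 mg/kg to 100 mg/kg.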

Compound 3, dose for half-maximal effect: 88.2 mg/kg
Compound 3: the middle estimate sits 2.0-fold (0.29 log units) below what was measured; low and high end bracket the measured number.
By their numbers in this assay, from the lowest: compounds 1, 2 and 3 (each within the scatter of the next, the first and the last beyond it).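

In this assay, replacing the group of 7 heavy atoms with the group of 6 heavy atoms, on a saturated chain carbon, three bonds along the chain from an aromatic nitrogen, gives a 2.1-fold higher number from compound 1 to compound 3 (0.32 log units; beyond the scatter). This is the first step among the compounds shown to pass beyond the scatter, whereas the earlier change gave only a 1.4-fold higher number from compound 1 to compound 2 (0.16 log units; within the scatter), so this part of the molecule is now seen to affect the dose needed, if modestly. The two groups match in their counted features apart from the heavy-atom total and its extra carbon, and no measurement available offers an explanation for the difference.

This rests on a single pair with a modest step, so the compounds shown cannot say whether the number would keep climbing with a still smaller group or fall with a longer chain. Nor do they show how an amine or a carboxylic acid at this position would compare with the sulfur-bearing groups, or whether the same step would appear on a core carrying another substituent in place of the phenyl group.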